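Aromatic methyl step compared across two cores

The compounds below may be only part of what the source reports. "The series", "measured", "known", "first", "only" and "open" are said of these compounds alone.

Compound 1 `C/C(=C\c1cc(-c2cccnc2)co1)C(N)=O` and compound 2 `C/C(=C\c1cc(-c2ccc(C)nc2)co1)C(N)=O` share one core; compound 3 `C/C(=C\c1cc(-c2ccccc2)cs1)C(N)=O` rests on another. In a functional assay on MCF7 cells (Homo sapiens) for cytotoxicity, read by CCK-8 assay, with a stated time of 24 h (a higher number here means a weaker inhibitor, a lower number a stronger inhibitor), compound 1 gives 13200 nM, and compound 2 gives 10200 nM. The step of a 1.3-fold lower number from compound 1 to compound 2 (0.11 log units; within the scatter) corresponds to methyl in place of hydrogen on an aromatic carbon. In this assay, within the data shown here, compound 3 gives 2680 nM, the lowest number of the three measured so far; the difference between its core and that of compound 1 is not broken down here.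

Compound 4 `C/C(=C\c1cc(-c2ccc(C)cc2)cs1)C(N)=O` has not yet been measured. It differs from compound 3 by methyl in place of hydrogen on an aromatic carbon. This is the same kind of change as that from compound 1 to compound 2, though the place differs: in compound 2 the methyl sits on a six-membered aromatic ring with 1 nitrogen, next to the ring nitrogen, whereas in compound 4 it sits on a six-membered aromatic ring of carbon only; both are para to a large group.

Because a 1.3-fold lower number from compound 1 to compound 2 (0.11 log units; within the scatter) lay within the scatter, a step of similar size is expected, namely a 1.3-fold lower number from compound 3 to compound 4 (0.11 log units; within the scatter). For compound 4 the expected value in this assay is 2100 nM, most likely between 900 nM and 5000 nM.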

Compound 4, half-maximal inhibitory concentration: > 50000 nM
Compound 4: no number, only a limit; the forecaster's own chance of this, stated with the estimate: 5%; middle value at least 23-fold (1.37 log units) away from the limit.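

On the core of compound 3, methyl in place of hydrogen on an aromatic carbon gives an at least 18-fold higher number from compound 3 to compound 4 (1.27 log units; beyond the scatter), and this does not match the step seen on the other core: the same change on two cores in this assay, a 1.3-fold lower number (0.11 log units; within the scatter) from compound 1 to compound 2 and an at least 18-fold higher number (1.27 log units; beyond the scatter) from compound 3 to compound 4, at least 24-fold (1.38 log units) apart, beyond the scatter of two such steps. Compound 4 gives > 50000 nM in this assay, which is a limit of the assay and not a number, and the step therefore fixes only a minimum size. The two pairs show that a within-scatter result for this change on one core did not predict its result on the other, but they do not show whether the core or the ring bearing the methyl, which contains nitrogen in compound 2 and is of carbon only in compound 4, accounts for the difference.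

Open, on these data alone, is how an amine, a carboxylic acid or a longer chain in place of the methyl on the ring of carbon only would read in this assay. Also open, as far as these compounds go, is how that ring, with or without the methyl, would read on the core of compound 1.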